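Replacing a methyl with methylsulfonyl on compound 2

The source may report more compounds than this note shows. Statements on the series, on what has been measured and on what is new or still open speak of the compounds shown alone.

Among the compounds with values here, in a functional assay on NCI-H146 cells (Homo sapiens) for cytotoxicity, with a stated time of 48 h, in the presence of a further agent that is not named here (on this read-out higher numbers stand for an effect only at larger amounts of compound and lower numbers for an effect already at smaller amounts), compound 2 `Cc1cc(S(=O)(=O)NC(=O)c2ccc(N3CCN(Cc4ccccc4-c4ccc(Cl)cc4)CC3)cc2)ccc1N[C@H](CCN(C)C)CSc1ccccc1` gives 28800 nM as the highest of the three numbers measured so far. Compound 1 `CN(C)CC[C@H](CSc1ccccc1)Nc1ccc(S(=O)(=O)NC(=O)c2ccc(N3CCN(Cc4ccccc4-c4ccc(Cl)cc4)CC3)cc2)cc1C(F)(F)F` gives 2460 nM by comparison. Differing from compound 2 in more than one place, compound 3 `CN(C)CC[C@H](CSc1ccccc1)Nc1ccc(S(=O)(=O)NC(=O)c2ccc(N3CCN(CC4=C(c5ccc(Cl)cc5)CCCCC4)CC3)cc2)cc1[N+](=O)[O-]` gives 51.9 nM and so offers no clean comparison for a single change. Compound 4 `CN(C)CC[C@H](CSc1ccccc1)Nc1ccc(S(=O)(=O)NC(=O)c2ccc(N3CCN(Cc4ccccc4-c4ccc(Cl)cc4)CC3)cc2)cc1S(C)(=O)=O` is still unmeasured. It carries methylsulfonyl in place of methyl on an aromatic carbon and is otherwise the same as compound 2. Within the data shown here, the one measured step at this carbon is a 12-fold higher number from compound 1 to compound 2 (1.07 log units; beyond the scatter) with methyl in place of trifluoromethyl, which is a large move. Among the measured compounds shown here, no measured compound in this set carries methylsulfonyl, so that step is only a rough guide. Still, compound 2 is the methyl member of that pair and holds the higher number, so removing methyl should lead downward. In this assay the expected move is a 19-fold lower number from compound 2 to compound 4 (1.28 log units; beyond the scatter) and so of similar size to the step with methyl in place of trifluoromethyl. Compound 4 is estimated at about 1500 nM with 250 nM to 8000 nM as the expected range.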

Compound 4, half-maximal effective concentration: 34900 nM
Compound 4: the middle estimate sits 23-fold (1.37 log units) below what was measured; measured number outside the range, above it.
By their numbers in this assay, from the lowest: compound 3; then compound 1; then compounds 2 and 4 (each within the scatter of the next).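

In this assay, putting methylsulfonyl in place of methyl on this aromatic carbon gives a 1.2-fold higher number from compound 2 to compound 4 (0.08 log units; within the scatter), so the larger group, with its added oxygens and sulfur, cannot be told apart from methyl here. Against trifluoromethyl the picture is also the same for both groups, with a 14-fold higher number from compound 1 to compound 4 (1.15 log units; beyond the scatter) alongside a 12-fold higher number from compound 1 to compound 2 (1.07 log units; beyond the scatter), which leaves compound 1 as the only one of these three with a clearly lower number. No measurement shown here accounts for this pattern.

From the compounds shown here alone, it remains open whether trifluoromethyl is unusual at this carbon or whether other groups, such as a chlorine atom or a nitrile, would also reach the lower range. A plain hydrogen at the same carbon would show how methyl and methylsulfonyl compare with having no group there at all.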